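The source may report more compounds than this note shows. Statements on the series, on what has been measured and on what is new or still open speak of the compounds shown alone.

In a functional assay on A549 cells (Homo sapiens) for antiproliferative activity, read by MTT assay, with a stated time of 72 h (a lower number here means a stronger inhibitor, a higher number a weaker inhibitor), compound 3 (`N=C(NS(=O)(=O)c1ccccc1Cl)N1CCN(c2cc3c(cc2F)c(=O)c(C(=O)O)cn3C2CC2)CC1`) gives 71 nM. Compound 1 (`N=C(NS(=O)(=O)c1ccccc1)N1CCN(c2cc3c(cc2F)c(=O)c(C(=O)O)cn3C2CC2)CC1`) gives 71 nM, and compound 2 (`CCn1cc(C(=O)O)c(=O)c2cc(F)c(N3CCN(C(=N)NS(=O)(=O)c4ccccc4Cl)CC3)cc21`) gives 71 nM, so compound 3 stands level with both. The next structure, compound 4 (`N=C(NS(=O)(=O)c1ccc(Cl)cc1)N1CCN(c2cc3c(cc2F)c(=O)c(C(=O)O)cn3C2CC2)CC1`), has the same atoms as compound 3, joined differently: 4-chlorophenyl in place of 2-chlorophenyl on a sulfonyl sulfur. In words, 4-chlorophenyl stands in place of 2-chlorophenyl on a sulfonyl sulfur.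

Two measured steps offer some guidance. Chloro in place of hydrogen on an aromatic carbon gave no change at the digits printed from compound 1 to compound 3 (within the scatter), and cyclopropyl in place of ethyl on an aromatic nitrogen gave no change at the digits printed from compound 2 to compound 3 (within the scatter). Neither step moves a chlorine, so nothing measured tests this change directly. Within the data shown here, the closest guide is the first step, where even the arrival of the chloro group left the reading unmoved. No shift beyond the scatter is therefore expected in this assay, in either direction, and the estimated step is no change at the digits printed from compound 3 to compound 4 (within the scatter). For compound 4 the estimate is 71 nM, with an expected range of 30 nM to 170 nM.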

Compound 4, half-maximal inhibitory concentration: 71 nM
Estimate against measurement, compound 4: no gap at the digits printed; the measured number falls inside the stated range.
By their numbers in this assay, from the lowest: compounds 1, 2, 3 and 4 (each within the scatter of the next).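

In this assay, 4-chlorophenyl in place of 2-chlorophenyl on the sulfonyl sulfur gives no change at the digits printed from compound 3 to compound 4 (within the scatter), the first direct test of where the chlorine sits, and the two placements cannot be told apart. Chloro in place of hydrogen on an aromatic carbon also gives no change at the digits printed from compound 1 to compound 4 (within the scatter), so the unmoved reading seen when chloro was first added to compound 1 holds for both chlorophenyl groups. No measurement shown here explains this flat result.

Since all four compounds read alike, they give no sign of what, if anything, would shift the number at this position. From the compounds shown here alone, it remains open whether an amine or a carboxylic acid on the aromatic ring in place of chloro, or a longer alkyl chain in place of the whole chlorophenyl group on the sulfonyl sulfur, would do so.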